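Side-chain swap on the ring amine nitrogen of compound 1

The source may report more compounds than this note shows. Statements on the series, on what has been measured and on what is new or still open speak of the compounds shown alone.

Compound 1 `CCO[C@@H](C)CN1CCC[C@H](Cn2c(-c3cccnc3C)nc3cn(-c4cccc(OC)c4)nc3c2=O)C1` stands second highest of the three numbers in an assay on HEK293 cells for displacement of a labelled ligand from growth hormone secretagogue receptor type 1 (Homo sapiens), with a stated time of 60 min; on this read-out lower numbers stand for stronger inhibition and higher numbers for weaker inhibition: compound 1 gives 5 nM. Nearest is compound 2 `Cc1ncccc1-c1nc2cn(-c3cccc(OC(F)F)c3)nc2c(=O)n1C[C@H]1CCCN(C[C@H]2CCCO2)C1`, which in this assay gives 27 nM, a higher number beyond the scatter; furthest is compound 3 `Cc1ccccc1-c1nc2cn(-c3ccc(Cl)cc3)nc2c(=O)n1CC1CCCN(C(C)C)C1`, which in this assay gives 0.28 nM, a lower number beyond the scatter. Compound 4 `COC[C@H](C)N1CCC[C@H](Cn2c(-c3cccnc3C)nc3cn(-c4cccc(OC)c4)nc3c2=O)C1` differs from compound 1 in one place: 1-(methoxymethyl)ethyl in place of 2-ethoxypropyl on an amine nitrogen in a ring, on an amine nitrogen in a ring of a six-membered non-aromatic ring with 1 nitrogen. Within the data shown here, no measured pair shows this step, so its size is unknown from the set. The change is small, and no step beyond the scatter is expected. Compound 4 is estimated at 6 nM, between 2 nM and 18 nM. The expected step is a 1.2-fold higher number from compound 1 to compound 4 (0.08 log units; within the scatter).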

Compound 4, half-maximal inhibitory concentration: 1.7 nM
For compound 4 the middle estimate is 3.5-fold (0.55 log units) above the measured one, and the stated range ends above it.
By their numbers in this assay, from the lowest: compound 3; then compound 4; then compound 1; then compound 2.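

On an amine nitrogen in a ring of the six-membered non-aromatic ring, 1-(methoxymethyl)ethyl in place of 2-ethoxypropyl gives a 2.9-fold lower number from compound 1 to compound 4 (0.47 log units; beyond the scatter) in this assay. This position therefore responds measurably to a change between two ether side chains, even though the hydrogen-bond donor and acceptor counts stay the same. Nothing available accounts for this step.

From the compounds shown here alone, it remains open whether the opposite configuration of 1-(methoxymethyl)ethyl keeps this number. Also open, going by these compounds, is how an amine or a carboxylic acid at the end of the side chain would read.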